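A few compounds are considered here, and "the series" means these few. Any claim that something is new, unique, unknown or untested is made for them only; others in the source may bear on it.

In an ADME assay on CHO cells for agonist activity at prostacyclin receptor (Homo sapiens), read by HTRF and cAMP accumulation (a lower number here means that less compound is needed, a higher number that more compound is needed for the effect), compound 1, `CS(=O)(=O)NC(=O)CCC/C=C\C[C@@H]1[C@@H](/C=C/[C@@H](O)COc2ccccc2)[C@H](O)C[C@@H]1O`, gives only a limit of the assay, > 10000 nM. Compound 2, `O=C(O)CCC1=CC[C@@H]2[C@@H](/C=C/[C@@H](O)COc3ccccc3)[C@H](O)C[C@@H]2OC1`, likewise gives only a limit in this assay, > 10000 nM. Compound 3, `O=C(O)CCCC1=CC[C@@H]2[C@@H](/C=C/[C@@H](O)COc3ccccc3)[C@H](O)C[C@@H]2OC1`, stands at a limit as well, > 10000 nM. Where compound 3 stands among the numbers shown is therefore not a number at all: every value shown sits at the limit of > 10000 nM in this assay, at which 3 of the 3 values shown sit, so no compound can be ranked against another, and the one step between measured compounds that differ in a single place, a step that the two limits leave unreadable from compound 2 to compound 3, runs from one limit to another and its size cannot be read. Compound 4, `O=C(O)CCCCC1=CC[C@@H]2[C@@H](/C=C/[C@@H](O)COc3ccccc3)[C@H](O)C[C@@H]2OC1`, differs from compound 3 by carboxymethyl in place of carboxy on a saturated chain carbon, three bonds along the chain from a double-bonded ring carbon. Among the measured compounds shown here, the only measured step that bears on this change is the one from compound 2 to compound 3, the same lengthening of the chain cut one bond further in, and it left no readable size. With nothing in the shown values pointing toward a measurable effect, compound 4 is expected to remain near the limit, at an estimated 12000 nM with a range from 3000 nM to 50000 nM, which amounts to an expected step that the limit leaves unreadable from compound 3 to compound 4.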

Compound 4, half-maximal effective concentration: > 10000 nM
Compound 4 gave a limit, no number; the forecaster's own chance of this, stated with the estimate: 75%; the middle value lies beyond the limit too.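

In this assay compound 4 gives > 10000 nM as a limit and not a number. Among the compounds shown here, the steps to compound 4 from compound 2 and compound 3 therefore cannot be read, and no compound can be ranked: the limit of > 10000 nM in this assay, at which 4 of the 4 values shown sit. The compounds shown leave open whether any chain length on the shared core gives a measurable value in this assay at all.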